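The source may hold more compounds than are shown below. What is called first, only, known or untested is meant among the compounds shown, and "the series" means these compounds.

In a functional assay on the whole organism with Rattus norvegicus as the target (on this read-out lower numbers stand for an effect already at smaller amounts and higher numbers for an effect only at larger amounts of compound), compound 1 `Nc1ccc2nc(N)sc2c1` reads > 10 mg/kg, which is a limit of the assay and not a number. Compound 2 `C[Si](C)(C)c1ccc2nc(N)sc2c1` gives 5 mg/kg, and compound 3 `CCCCCc1ccc2nc(N)sc2c1` gives 7.5 mg/kg. These last two numbers cannot be told apart, since the measured step is a 1.5-fold higher number from compound 2 to compound 3 (0.18 log units; within the scatter). Compound 3 therefore stands level with compound 2 within the scatter.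

Compound 4 `CCC(C)(C)c1ccc2nc(N)sc2c1` has 1,1-dimethylpropyl in place of pentyl on an aromatic carbon. Among the compounds with values here, no measured step makes this exact exchange. The closest guide is the change of group at that same aromatic carbon in the step already given between compound 2 and compound 3, which stayed within the scatter. The step of an at least 1.3-fold lower number from compound 1 to compound 3 (0.12 log units; that floor lies within the scatter) adds little, as it rests on (the limit of > 10 mg/kg in this assay, at which 1 of the 3 values shown sits). No change beyond the scatter is therefore expected in this assay, and no direction can be supported with confidence. The expected step is a 1.3-fold lower number from compound 3 to compound 4 (0.10 log units; within the scatter). For compound 4, the estimated value is 6 mg/kg, with an expected range of 3 mg/kg to 12 mg/kg.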

Compound 4, dose for half-maximal effect: > 10 mg/kg
Compound 4 ended at the assay's limit; the forecaster's own chance of this, stated with the estimate: 15%; middle value at least 1.6-fold (0.22 log units) away from the limit.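

At an aromatic carbon of the shared core, putting 1,1-dimethylpropyl in place of pentyl keeps the same atoms and joins them differently, and in this assay this exchange gives an at least 1.3-fold higher number from compound 3 to compound 4 (0.12 log units; that floor lies within the scatter). Set against the group of 4 heavy atoms that carries silicon, the same 1,1-dimethylpropyl group gives an at least 2.0-fold higher number from compound 2 to compound 4 (0.30 log units; that floor lies within the scatter), while the step that links the amino group of the core of compound 1 to this group cannot be read. Compound 4 stands at a limit of the assay and not at a number, so neither floor yet separates this rearrangement of the atoms from the scatter: the limit of > 10 mg/kg in this assay, at which 2 of the 4 values shown sit.

Going by these compounds, how far compound 4 lies past that limit stays open, and with it whether the way the atoms are joined matters at this position at all. The compounds shown also leave open how an isopropyl group, a tert-butyl group or a longer chain such as heptyl would read at this carbon in this assay.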